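The source may report more compounds than this note shows. Statements on the series, on what has been measured and on what is new or still open speak of the compounds shown alone.

Of the compounds shown here, three have been measured in an assay on cells for inhibition of HSP60/HSP10 (Homo sapiens), with a stated time of 60 min; on this read-out higher numbers stand for weaker inhibition and lower numbers for stronger inhibition. Compound 1 `O=S(=O)(Nc1ccc(-c2nc3ccccc3o2)cc1)c1ccc(Cl)s1` gives 31000 nM, compound 2 `O=S(=O)(Nc1ccc2oc(-c3ccccc3)nc2c1)c1ccc(O)cc1` gives 88000 nM, and compound 3 `O=S(=O)(Nc1ccc(-c2nc3cc(NS(=O)(=O)c4ccc(O)cc4)ccc3o2)cc1)c1ccc(O)cc1` gives 14000 nM. Compound 2 thus has the highest number of the three: compound 1 sits nearest below it, and compound 3 is furthest away, with a 6.3-fold lower number from compound 2 to compound 3 (0.80 log units; beyond the scatter). Compound 4 `O=S(=O)(Nc1ccc2oc(-c3ccccc3)nc2c1)c1cccc(Cl)c1` differs from compound 2 by 3-chlorophenyl in place of 4-hydroxyphenyl on a sulfonyl sulfur. For the measured compounds named here, no measured step touches this place: the one measured step changes a different part of compound 2, so it gives no guide to the size or direction of the change here. Without such guidance, the expected step is a 1.8-fold lower number from compound 2 to compound 4 (0.25 log units; within the scatter), hardly beyond the scatter. Compound 4 is therefore estimated at 50000 nM, within a range from 15000 nM to 160000 nM.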

Compound 4, half-maximal inhibitory concentration: > 100000 nM
Compound 4: no number, only a limit; the forecaster's own chance of this, stated with the estimate: 20%; middle value at least 2.0-fold (0.30 log units) away from the limit.
By their numbers in this assay, from the lowest: compound 3; then compound 1; then compound 2. At a limit, above all of these: compound 4.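

In this assay compound 4 has no number, only a limit: the limit of > 100000 nM in this assay, at which 1 of the 4 values shown sits.

Placing 3-chlorophenyl instead of 4-hydroxyphenyl on the sulfonyl sulfur, the only change shown at this place, gives an at least 1.1-fold higher number from compound 2 to compound 4 (0.05 log units; that floor lies within the scatter). This swap brings no lower number, but the true size of the step stays hidden.

The swap removes the hydroxy group and adds the chlorine together, and the compounds shown do not separate the two. As far as these compounds go, what an unsubstituted phenyl, or an amine or carboxylic acid on this ring, would do remains open.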